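Side-Chain Variants of a Flavanone Core and Colon Cell Cytotoxicity

The source may report more compounds than this note shows. Statements on the series, on what has been measured and on what is new or still open speak of the compounds shown alone.

The measured compounds and their values:
Compound 1 `COC(C)(C)/C=C/C/C(C)=C/Cc1c(O)ccc2c1O[C@H](c1ccc(O)cc1)CC2=O` gives > 10000 nM in a functional assay on HT-29 cells (Homo sapiens) for cytotoxicity, read by MTT assay (a higher number here means a weaker inhibitor, a lower number a stronger inhibitor), which is a limit of the assay rather than a number.
Compound 2 `C=C(C)C(O)CC/C(C)=C/Cc1c(O)ccc2c1O[C@H](c1ccc(O)cc1)CC2=O` gives > 10000 nM in this assay, again a limit.
Compound 3 `CC1=CCC(O)C(C)(C)C1Cc1c(O)ccc2c1O[C@H](c1ccc(O)cc1)CC2=O` gives > 10000 nM in this assay, once more a limit.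

Compound 3 thus stands at the limit, as do the two other measured compounds: the limit of > 10000 nM in this assay, at which 3 of the 3 values shown sit. The two steps between measured neighbours, a step that the two limits leave unreadable from compound 1 to compound 2 and a step that the two limits leave unreadable from compound 2 to compound 3, cannot be given a size, since each connects two limits.

Compound 4 `CC(C)=CCC/C(C)=C/Cc1c(O)ccc2c1O[C@H](c1ccc(O)cc1)CC2=O` has not yet been measured. It differs from compound 3 in one place: 2,6-dimethylhepta-1,5-dien-1-yl in place of 5-hydroxy-2,6,6-trimethylcyclohex-2-en-1-yl on a saturated chain carbon bound to an aromatic carbon. The side chain of compound 4 resembles that of compounds 1 and 2 in being open, and both of those compounds sit at the limit. Neither measured step gives a readable size, so no step beyond the scatter can be expected in this assay in either direction. Compound 4 is therefore estimated at 15000 nM, with a range from 4000 nM to 60000 nM, and the expected step is a step that the limit leaves unreadable from compound 3 to compound 4, most likely reported again as a limit.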

Compound 4, half-maximal inhibitory concentration: > 10000 nM
Compound 4: only a limit was reported; the forecaster's own chance of this, stated with the estimate: 80%; the middle value lies beyond the limit too.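

Compound 4 gives > 10000 nM in this assay as a limit of the assay, not a number. Its steps from compound 1, compound 2 and compound 3 each join two limits and cannot be read. Still open, on these data alone, is which side chain on the shared core, if any, would give a measurable value in this assay at all.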